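The source may report more compounds than this note shows. Statements on the series, on what has been measured and on what is new or still open speak of the compounds shown alone.

Compound 1 `O=C(Nc1cc(Sc2ncn[nH]2)c(O)c2ccccc12)c1cccc(Cl)c1`; in a functional assay on HCT-116 cells (Homo sapiens) for antiproliferative activity, read by MTT assay, with a stated time of 48 h (a higher number here means a weaker inhibitor, a lower number a stronger inhibitor), compound 1 gives > 100000 nM, a limit of the assay.
Compound 2 `COc1ccc(/C=C/C(=O)Nc2cc(Sc3ncn[nH]3)c(O)c3ccccc23)cc1OC`; in this assay compound 2 gives > 100000 nM, a limit of the assay.
Compound 3 `COc1ccc(C(=O)Nc2cc(Sc3ncn[nH]3)c(O)c3ccccc23)cc1`; in this assay compound 3 gives > 100000 nM, a limit of the assay.

Compound 3 therefore stands nowhere on a numerical scale: its value is a limit, and the same holds for the two companions shown beside it, all three sitting at the limit of > 100000 nM in this assay, at which 3 of the 3 values shown sit. Going by the values given here, the one step that touches compound 3, a step that the two limits leave unreadable from compound 1 to compound 3, cannot be sized because a step that the two limits leave unreadable from compound 1 to compound 3 runs between two limits.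

Compound 4 `O=C(/C=C/c1ccc(Cl)cc1)Nc1cc(Sc2ncn[nH]2)c(O)c2ccccc12` differs from compound 3 in one place: 2-(4-chlorophenyl)ethenyl in place of 4-methoxyphenyl on a carbonyl carbon. Among the compounds with values here, no measured step gives a readable size for this kind of change. Compound 2, which also carries a double bond outside aromatic rings on the carbonyl carbon, likewise rests at the limit, so nothing shown points to a gain in potency from the new group.

The expectation for compound 4 is therefore that in this assay it will again report a limit, estimated at 150000 nM with a range from 50000 nM to 500000 nM. The expected step, a step that the limit leaves unreadable from compound 3 to compound 4, is thus no readable change beyond the scatter.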

Compound 4, half-maximal inhibitory concentration: > 100000 nM
Compound 4 gave a limit, no number; the forecaster's own chance of this, stated with the estimate: 80%; the middle value does not contradict the limit.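

Compound 4 also returns only a limit in this assay, so its steps from compound 1, compound 2 and compound 3 cannot be read, and all four compounds rest at the same limit: the limit of > 100000 nM in this assay, at which 4 of the 4 values shown sit. The compounds shown leave open whether any group on the carbonyl carbon of the shared core can give a measurable value in this assay.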